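Nitro in place of hydrogen on compound 2

A few compounds are considered here, and "the series" means these few. Any claim that something is new, unique, unknown or untested is made for them only; others in the source may bear on it.

Measured so far in a functional assay on K-562R cells (Homo sapiens) for cytotoxicity, read by MTT assay, with a stated time of 48 h; on this read-out higher numbers stand for weaker inhibition and lower numbers for stronger inhibition:
- compound 1 `COc1ccc(-c2cn(C(=O)Nc3cc(OC)c(OC)c(OC)c3)c(=O)n2-c2cc(OC)c(OC)c(OC)c2)cc1O`: > 50000 nM (a limit of the assay)
- compound 2 `COc1cc(-n2c(-c3ccccc3)cn(C(C)=O)c2=O)cc(OC)c1OC`: 9600 nM

Compound 1 gives the reading > 50000 nM, which is a limit of the assay and not a number. Among the compounds with values here, compound 2 gives 9600 nM as the only actual number so far, and it is therefore the sole anchor for what follows.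

The next compound is compound 3 `COc1cc(-n2c(-c3ccc([N+](=O)[O-])cc3)cn(C(C)=O)c2=O)cc(OC)c1OC`, which differs from compound 2 by a single change: nitro in place of hydrogen on an aromatic carbon. In words, nitro replaces hydrogen on an aromatic carbon, turning phenyl into 4-nitrophenyl.

Within the data shown here, no measured step covers this change, and the expectation rests on compound 2 at 9600 nM alone. In this assay a small step is expected, close to the usual scatter and leaning slightly towards stronger inhibition, with the direction uncertain. The estimated 1.2-fold lower number from compound 2 to compound 3 (0.08 log units; within the scatter) is accordingly modest. For compound 3 the expected value is 8000 nM, with an estimated range of 2500 nM to 27000 nM as the likely span.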

Compound 3, half-maximal inhibitory concentration: 49600 nM
Estimate against measurement, compound 3: 6.2-fold (0.79 log units) below, and the stated range ends below it.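

In this assay, within the data shown here, turning phenyl into 4-nitrophenyl gives a 5.2-fold higher number from compound 2 to compound 3 (0.71 log units; beyond the scatter), the first change in a single place that can be read. This aromatic carbon, para to a large group, therefore does not tolerate every replacement of hydrogen: with nitro in place of hydrogen, the pair moves towards weaker inhibition, and compound 2 remains its stronger member. A further loss of activity from this position would have little room to be sized in this assay, so the reading for the nitro compound marks a practical end of the useful range rather than a comfortable point from which to compare further changes: the limit of > 50000 nM in this assay, at which 1 of the 3 values shown sits.

With only one substituent read at this carbon, the step cannot separate an effect specific to nitro from a more general intolerance of any group placed there. As far as these compounds go, an amine or a single fluorine atom on the same carbon would test that distinction, and a carboxylic acid would extend it, while the effect of moving nitro to another carbon of the same ring also remains open.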